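The compounds below may be only part of what the source reports. "The series", "measured", "known", "first", "only" and "open" are said of these compounds alone.

Compound 1 `CCC(=O)N[C@@H]1CCCc2c1cncc2N1CCc2cc(Cl)ccc2C1=O` gives in an ADME assay on microsomes from liver (Rattus norvegicus) for metabolic stability, read by LC-MS, using NADPH, with stated times of 10 min and 30 min (a lower number here means slower removal, a higher number faster removal of the compound), only a limit, < 20.2 mL/min/kg.
Compound 2 `CS(=O)(=O)N[C@@H]1CCCc2c1cncc2N1CCc2cc(Cl)ccc2C1=O` gives only a limit, < 20.2 mL/min/kg.
Compound 3 `CC(=O)N1CCN(c2cncc(N3C(=O)c4ccc(Cl)cc4C3(C)C)c2)CC1` gives 17.7 mL/min/kg.

Among the compounds with values here, compound 3 thus stands as the only compound with a real number; the two others sit at the limit of < 20.2 mL/min/kg in this assay, at which 2 of the 3 values shown sit. Compound 4 `CC1(C)c2cc(Cl)ccc2C(=O)N1c1cncc(N2CCN(S(C)(=O)=O)CC2)c1` differs from compound 3 by methylsulfonyl in place of acetyl on an amine nitrogen in a ring. Within the data shown here, the single measured step, a step that the two limits leave unreadable from compound 1 to compound 2, also places methylsulfonyl on an amine nitrogen, but its size cannot be carried over. Compound 2, which bears that methylsulfonyl, still sits at the limit rather than at a high clearance. The change expected for compound 4 is therefore a 1.1-fold lower number from compound 3 to compound 4 (0.04 log units; within the scatter), nothing beyond the usual scatter. Compound 4 is estimated at 16 mL/min/kg, with a range from 8 mL/min/kg to 30 mL/min/kg.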

Compound 4, clearance: 16.8 mL/min/kg
Beside the measured number, compound 4's estimate is 1.1-fold (0.02 log units) below it; the measured number falls inside the stated range.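

In this assay, within the data shown here, the exchange of acetyl for methylsulfonyl on an amine nitrogen in a ring gives a step of readable size for the first time (a 1.1-fold lower number from compound 3 to compound 4 (0.02 log units; within the scatter)). On this six-membered non-aromatic ring with 2 nitrogen, the exchange therefore leaves clearance within the scatter. The earlier step, with methylsulfonyl in place of propanoyl, cannot be read: the limit of < 20.2 mL/min/kg in this assay, at which 2 of the 4 values shown sit.

The compounds shown leave open whether another group on this nitrogen, such as a longer acyl chain, a carboxylic acid or a free amine, would move clearance beyond the scatter. They also leave open the size of any methylsulfonyl step in the core of compound 1.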